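Dropping a Methoxy Group From a Weak Starting Compound

This account rests on a few compounds, and the source may have more. Where it says the series, first, only, none or still open, it means among the compounds named here.

Compound 1 `COc1ccc2oc(-c3cn4nc(OC)sc4n3)cc2c1` gave > 30000 nM in an assay on a cell-free system (plasma) for antagonist activity at proteinase-activated receptor 4 (Homo sapiens), with a stated time of 5 min, in the presence of a further agent that is not named here (on this read-out higher numbers stand for weaker inhibition and lower numbers for stronger inhibition), a limit of the assay rather than a number.
Compound 2 `COc1cc(OCc2ccccc2OCc2ccccc2)c2cc(-c3cn4nc(OC)sc4n3)oc2c1` gave 2500 nM in this assay.

Compound 1 thus stands at the weak end of the two numbers shown, with only a limit recorded (the limit of > 30000 nM in this assay, at which 1 of the 2 values shown sits). Compound 3 `COc1nn2cc(-c3cc4ccccc4o3)nc2s1` differs from compound 1 by hydrogen in place of methoxy on an aromatic carbon. Among the compounds with values here, no measured step links these two compounds, so only an expectation is possible: no change beyond the usual scatter is expected, and the expected step of a number no higher from compound 1 to compound 3 (the limit leaves the size open) is therefore flat. Compound 3 is expected near 30000 nM, estimated within 10000 nM to 100000 nM, most likely again only a limit.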

Compound 3, half-maximal inhibitory concentration: 15000 nM
The estimate for compound 3 lay 2.0-fold (0.30 log units) above the measured number; the range from low to high includes it.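

Hydrogen in place of methoxy on the six-membered aromatic ring of carbon only gives an at least 2.0-fold lower number from compound 1 to compound 3 (0.30 log units; that floor lies within the scatter). The methoxy at this position is therefore not required for compound 3 to give a measurable number, yet the floor alone does not show a real gain. The true size of the step stays unknown because compound 1 has only a limit: the limit of > 30000 nM in this assay, at which 1 of the 3 values shown sits.

As far as these compounds go, whether an amine, a carboxylic acid or a longer chain such as butoxy on this carbon would move the number remains open.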